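What One Group Swap May Do to Cytotoxicity

The source may report more compounds than this note shows. Statements on the series, on what has been measured and on what is new or still open speak of the compounds shown alone.

In a functional assay on MDA-MB-231 cells (Homo sapiens) for cytotoxicity, read by MTT assay, with a stated time of 48 h (on this read-out lower numbers stand for stronger inhibition and higher numbers for weaker inhibition), compound 3 `COc1ccc(C2=NOC(COc3ccc(-c4nnnn4-c4cc(OC)c(OC)c(OC)c4)cc3N)C2)cc1O` gives 3380 nM. Compound 1 `COc1ccc(OC)c(C2=NOC(COc3ccc(-c4nnnn4-c4cc(OC)c(OC)c(OC)c4)cc3N)C2)c1` gives 3500 nM and compound 2 `COc1cc(C2=NOC(c3cc(OC)c(OC)c(OC)c3)C2)ccc1O` gives 3600 nM, so all three values lie within the usual scatter of one another. Compound 4 `COc1cc(-n2nnnc2-c2ccc(OCC3CC(c4ccc(C(F)(F)F)cc4)=NO3)c(N)c2)cc(OC)c1OC` alters a single group of compound 3: 4-(trifluoromethyl)phenyl in place of 3-hydroxy-4-methoxyphenyl on a carbon with a double bond to nitrogen. Going by the values given here, only one measured step changes a group at this same place, a 1.0-fold lower number from compound 1 to compound 3 (0.02 log units; within the scatter), and it stayed within the scatter. Among the compounds with values here, no measured compound carries 4-(trifluoromethyl)phenyl, however, so this evidence is thin and the range must stay wide. In this assay, no shift beyond the scatter is expected, and the estimated change is a 1.1-fold lower number from compound 3 to compound 4 (0.05 log units; within the scatter). For compound 4 the expected value is 3000 nM, with an estimated range of 1200 nM to 8000 nM.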

Compound 4, half-maximal inhibitory concentration: 1750 nM
For compound 4 the middle estimate is 1.7-fold (0.23 log units) above the measured one; measured number inside the range.
By their numbers in this assay, from the lowest: compounds 4, 3, 1 and 2 (each within the scatter of the next, the first and the last beyond it).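

In this assay, the carbon with a double bond to nitrogen accepts 4-(trifluoromethyl)phenyl with a 1.9-fold lower number from compound 3 to compound 4 (0.29 log units; within the scatter) and with a 2.0-fold lower number from compound 1 to compound 4 (0.30 log units; within the scatter) as the two steps. So neither the hydroxy and methoxy groups of compound 3 nor the two methoxy groups of compound 1 are needed to keep the number in this range. Nothing measured here explains why the number holds at this position. The compounds shown leave open whether a phenyl ring carrying an amine or a carboxylic acid, or a longer chain in place of the ring, would also hold it.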